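From Hydroxy to Methoxy on Compound 2

A few compounds are considered here, and "the series" means these few. Any claim that something is new, unique, unknown or untested is made for them only; others in the source may bear on it.

In a functional assay on MCF7 cells (Homo sapiens) for cytotoxicity, read by sulforhodamine B assay, with a stated time of 48 h (a lower number here means a stronger inhibitor, a higher number a weaker inhibitor), compound 2 `COc1cc(/C=C/C(=O)c2ccc(N)c(-c3ccc(F)cc3)c2)ccc1O` gives 10500 nM. Compound 3 `COc1ccccc1/C=C/C(=O)c1cccc(-c2cccc(F)c2)c1` gives 18900 nM, within the scatter of compound 2, while compound 1 `COc1cc(/C=C/C(=O)c2ccc(N)c(-c3ccc(F)cc3)c2)cc(Br)c1O` gives 40500 nM. Compound 4 `COc1ccc(/C=C/C(=O)c2ccc(N)c(-c3ccc(F)cc3)c2)cc1OC` has not yet been measured. It differs from compound 2 by methyl in place of hydrogen on an oxygen on an aromatic ring, with methyl in place of hydrogen on an oxygen on an aromatic ring, which reads as hydroxy to methoxy. For the measured compounds named here, the only measured step, a 3.9-fold lower number from compound 1 to compound 2 (0.59 log units; beyond the scatter), is a modest one that puts hydrogen in place of bromo on an aromatic carbon. It is a different change, so it bears only loosely on this one, and no shift beyond the scatter is expected. The expected step is a 1.3-fold higher number from compound 2 to compound 4 (0.12 log units; within the scatter). For compound 4, the estimated value is 14000 nM, with an expected range of 5000 nM to 40000 nM.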

Compound 4, half-maximal inhibitory concentration: 15000 nM
Beside the measured number, compound 4's estimate is 1.1-fold (0.03 log units) below it; the range from low to high includes it.
By their numbers in this assay, from the lowest: compounds 2, 4 and 3 (each within the scatter of the next); then compound 1.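

Methyl in place of hydrogen on an oxygen on an aromatic ring gives a 1.4-fold higher number from compound 2 to compound 4 (0.15 log units; within the scatter) in this assay and so stays within the scatter. The earlier step (a 3.9-fold lower number from compound 1 to compound 2 (0.59 log units; beyond the scatter)) showed a change beyond the scatter on exchanging bromo for hydrogen, whereas this hydroxy group can be replaced by methoxy with no such shift. Nothing available explains this result.

Going by these compounds, whether an ethyl or a benzyl group on this oxygen would also stay within the scatter of compound 2 remains open. So does the outcome of an amine in place of the methoxy.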